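Urea variation on the sulfonamide aryl of the oxadiazole series

The compounds below may be only part of what the source reports. "The series", "measured", "known", "first", "only" and "open" are said of these compounds alone.

Compound 1 `NS(=O)(=O)c1ccc(S(=O)(=O)Nc2cccc(-c3nc(-c4ccc(NC(=O)c5cccnc5)cc4Cl)no3)c2)cc1` carries a sulfamoyl group on the sulfonamide aryl. In a functional assay on MDA-MB-231 cells (Homo sapiens) for antiproliferative activity, read by MTT assay, with a stated time of 72 h (on this read-out higher numbers stand for weaker inhibition and lower numbers for stronger inhibition), compound 1 gives only a limit, > 10000 nM. Compound 2 `CC(=O)Nc1ccc(S(=O)(=O)Nc2cccc(-c3nc(-c4ccc(NC(=O)c5cccnc5)cc4Cl)no3)c2)cc1` gives 2500 nM in this assay, and compound 3 `CNC(=O)Nc1ccc(S(=O)(=O)Nc2cccc(-c3nc(-c4ccc(NC(=O)c5cccnc5)cc4Cl)no3)c2)cc1` gives 1300 nM; the pair sits within the scatter, with a 1.9-fold lower number from compound 2 to compound 3 (0.28 log units; within the scatter). Compound 4 `O=C(Nc1ccc(-c2noc(-c3cccc(NS(=O)(=O)c4ccc(NC(=O)N5CCCC5)cc4)c3)n2)c(Cl)c1)c1cccnc1` differs from compound 3 in one place: pyrrolidin-1-yl in place of methylamino on a carbonyl carbon. Among the compounds with values here, the only measured step at the same carbonyl carbon is the one from compound 2 to compound 3, and it was within the scatter; the steps of an at least 4.0-fold lower number from compound 1 to compound 2 (0.60 log units; beyond the scatter) and an at least 7.6-fold lower number from compound 1 to compound 3 (0.88 log units; beyond the scatter) concern the other end of the group. No step beyond the scatter is therefore expected for compound 4, a 1.4-fold higher number from compound 3 to compound 4 (0.14 log units; within the scatter). Compound 4 is estimated at 1800 nM, in the range 600 nM to 5500 nM.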

Compound 4, half-maximal inhibitory concentration: 5800 nM
Compound 4: middle estimate off by 3.2-fold (0.51 log units), on the low side; measured number outside the range, above it.
By their numbers in this assay, from the lowest: compounds 3 and 2 (each within the scatter of the next); then compound 4. At a limit, above all of these: compound 1.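

The substituent on this carbonyl carbon does matter: in this assay pyrrolidin-1-yl in place of methylamino gives a 4.5-fold higher number from compound 3 to compound 4 (0.65 log units; beyond the scatter) while methylamino in place of methyl stayed within the scatter. The same position also separates the acetamido compound, with a 2.3-fold higher number from compound 2 to compound 4 (0.37 log units; beyond the scatter) as the step for pyrrolidin-1-yl in place of methyl. The comparison with the sulfamoyl compound reads an at least 1.7-fold lower number from compound 1 to compound 4 (0.23 log units; that floor lies within the scatter) and rests on a limit: the limit of > 10000 nM in this assay, at which 1 of the 4 values shown sits.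

The compounds shown do not separate the loss of the hydrogen-bond donor from the added ring. Dimethylamino or ethylamino on the same carbonyl carbon would bear on that.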